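Shortening the Diester Linker in a Retinoid Amide Series

The compounds below may be only part of what the source reports. "The series", "measured", "known", "first", "only" and "open" are said of these compounds alone.

Compound 1, `Cc1cc2c(cc1C(=O)c1ccc(C(=O)OCCCCOC(=O)c3ccc(C(=O)Nc4ccc5c(c4)C(C)(C)CCC5(C)C)cc3)cc1)C(C)(C)CCC2(C)C`, gives 24700 nM in a functional assay on HL-60 cells (Homo sapiens) for inhibition, read by MTT assay, with a stated time of 48 h; a lower number here means a stronger inhibitor, a higher number a weaker inhibitor.
Compound 2, `CCCC(=O)OCCCCOC(=O)c1ccc(C(=O)Nc2ccc3c(c2)C(C)(C)CCC3(C)C)cc1`, gives 7320 nM in this assay.
Compound 3, `Cc1cc2c(cc1C(=O)c1ccc(C(=O)OCCCOC(=O)c3ccc(C(=O)Nc4ccc5c(c4)C(C)(C)CCC5(C)C)cc3)cc1)C(C)(C)CCC2(C)C`, gives 14900 nM in this assay.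

Among these three numbers compound 2 stands lowest. Compound 3 returns a higher number than compound 2, and the gap lies beyond the usual scatter; compound 1 returns a higher number still, and that gap too lies beyond the scatter. Compound 1 and compound 3 share a second amide-bearing core at the far end of the diester chain, whereas compound 2 carries only a butyryl ester there, and nothing in the record ties the ordering to any one part of the molecules.

Compound 4, `CCCC(=O)OCCOC(=O)c1ccc(C(=O)Nc2ccc3c(c2)C(C)(C)CCC3(C)C)cc1`, is compound 2 with a shorter linker: (propylcarbonyl)oxy in place of 2-((propylcarbonyl)oxy)ethyl on a saturated chain carbon, two bonds along the chain from an oxygen next to a carbonyl group. Within the data shown here, no measured pair isolates a change of this kind, so there is no step to lean on. Given that compound 2 gives 7320 nM and that the chain is the only thing altered, compound 4 is expected to land close to compound 2, with a change of a 1.2-fold lower number from compound 2 to compound 4 (0.09 log units; within the scatter) that stays within the scatter, in either direction. The estimate for compound 4 in this assay is 6000 nM, with a range from 2500 nM to 15000 nM.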

Compound 4, half-maximal inhibitory concentration: 6290 nM
Estimate against measurement, compound 4: 1.0-fold (0.02 log units) below, and the stated range covers the measured number.
By their numbers in this assay, from the lowest: compounds 4 and 2 (each within the scatter of the next); then compounds 3 and 1 (each within the scatter of the next).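

In this assay, among these compounds, the replacement of 2-((propylcarbonyl)oxy)ethyl by (propylcarbonyl)oxy gives a 1.2-fold lower number from compound 2 to compound 4 (0.07 log units; within the scatter) and is the only step here that isolates a single change. On a saturated chain carbon, two bonds along the chain from an oxygen next to a carbonyl group, this shortening of the linker therefore leaves the read-out within the scatter, so the butyl and ethyl diester linkers cannot be told apart in this cell assay. No measured property or other outside evidence bears on why the number holds across this change, and the result gives no ground for assigning any role to the linker.

The compounds shown leave open whether this tolerance extends beyond these two linkers, for instance to a longer chain such as a hexyl linker or to a linker carrying an amine. They also leave open whether replacing the terminal butyryl ester with a free carboxylic acid would move the number, and whether the linker change would behave the same way on the larger diesters.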